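Hydroxyphenyl Ketone Expected After Weak Pyrrolyl Analogue

The compounds below may be only part of what the source reports. "The series", "measured", "known", "first", "only" and "open" are said of these compounds alone.

The series shares one core and is judged in a functional assay on SK-OV-3 cells (Homo sapiens) for cytotoxicity, read by MTT assay, with a stated time of 48 h; a higher number here means a weaker inhibitor, a lower number a stronger inhibitor. For the measured compounds named here, compound 1 `Cn1cccc1C(=O)/C=C/c1ccc2c(c1)B(O)OC2` carries a 1-methyl-1H-pyrrol-2-yl group on the carbonyl carbon, and in this assay compound 1 gives 93600 nM, the highest of the three numbers known so far. Compound 2 `O=C(/C=C/c1ccc2c(c1)B(O)OC2)c1ccc(C(F)(F)F)cc1` gives 3700 nM in this assay, and compound 3 `O=C(/C=C/c1ccc2c(c1)B(O)OC2)c1ccc(Cl)c(Cl)c1` gives 1800 nM; both lie beyond the scatter from compound 1, compound 2 being the nearest to it and compound 3 the furthest. Compound 4 `O=C(/C=C/c1ccc2c(c1)B(O)OC2)c1cccc(O)c1` has not yet been measured. It differs from compound 1 in one place (3-hydroxyphenyl in place of 1-methyl-1H-pyrrol-2-yl on a carbonyl carbon). Going by the values given here, no pair of measured compounds differs in only one place, so the expectation rests on the observation that the two compounds bearing a six-membered aromatic ring of carbon only on the carbonyl carbon, compound 2 at 3700 nM and compound 3 at 1800 nM, give far lower numbers than compound 1. In this assay the expected step is therefore a 12-fold lower number from compound 1 to compound 4 (1.07 log units; beyond the scatter), a decrease beyond the scatter, though smaller than what compound 2 and compound 3 show. For compound 4 the estimated value is 8000 nM, with a range from 2500 nM to 30000 nM.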

Compound 4, half-maximal inhibitory concentration: 3800 nM
Beside the measured number, compound 4's estimate is 2.1-fold (0.32 log units) above it; the range from low to high includes it.
By their numbers in this assay, from the lowest: compound 3; then compounds 2 and 4 (each within the scatter of the next); then compound 1.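

For the compounds shown here, putting 3-hydroxyphenyl in place of 1-methyl-1H-pyrrol-2-yl on a carbonyl carbon gives, in this assay, a 25-fold lower number from compound 1 to compound 4 (1.39 log units; beyond the scatter), the first step that can be read at this single place, and it shows directly that this position strongly moves the number. Compound 4 carries neither the trifluoromethyl group of compound 2 nor the two chlorines of compound 3, yet compound 2 at 3700 nM and compound 4 at 3800 nM lie within the scatter of each other, so among the compounds shown a low number at this position is not confined to halogen-bearing rings. No measurement here speaks to what lies behind the step.

A plain phenyl on the carbonyl carbon would be needed to tell how much of the step belongs to the change of ring and how much to the hydroxyl group. Going by these compounds, it also remains open whether an amine or a carboxylic acid in place of that hydroxyl group would keep the number in this assay this low, and whether a pyrrole lacking the methyl group would stay as weak as compound 1.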